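This account rests on a few compounds, and the source may have more. Where it says the series, first, only, none or still open, it means among the compounds named here.

Measured so far in a functional assay (aorta) with Rattus norvegicus as the target; a lower number here means that less compound is needed, a higher number that more compound is needed for the effect:
Compound 1 `CN(C)/C(=N\C#N)C1=CC(C)(C)Oc2ccc([N+](=O)[O-])cc21` gives > 31600 nM, a limit of the assay.
Compound 2 `CN(C)/C(=N\C#N)C1=CC(C)(C)Oc2ccc(Br)cc21` gives > 31600 nM, likewise a limit of the assay.

Compound 1 thus stands only at the limit of > 31600 nM in this assay, at which 2 of the 2 values shown sit, with no number of its own. Within the data shown here, the single measured step, a step that the two limits leave unreadable from compound 1 to compound 2, cannot be read because the limit of > 31600 nM in this assay, at which 2 of the 2 values shown sit, covers both of its ends. Compound 3 `CN(C)C(=S)C1=CC(C)(C)Oc2ccc([N+](=O)[O-])cc21` differs from compound 1 by a group of 5 heavy atoms (3 carbon, 1 nitrogen, 1 sulfur; no ring) in place of a group of 7 heavy atoms (4 carbon, 3 nitrogen; no ring), on a double-bonded ring carbon. Among the measured compounds shown here, no measured step bears on this change, so neither a direction nor a size beyond the scatter can be drawn from the series; the only anchor is the limit at which compound 1 sits. Compound 3 is therefore expected near 25000 nM, within 4000 nM to 150000 nM, and the implied step an at least 1.2-fold lower number from compound 1 to compound 3 (0.10 log units; that floor lies within the scatter) is an estimate only.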

Compound 3, half-maximal effective concentration: 955 nM
For compound 3 the middle estimate is 26-fold (1.42 log units) above the measured one; measured number outside the range, below it.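

On the double-bonded ring carbon, a group of 5 heavy atoms (3 carbon, 1 nitrogen, 1 sulfur) in place of a group of 7 heavy atoms (4 carbon, 3 nitrogen) gives an at least 33-fold lower number from compound 1 to compound 3 (1.51 log units; beyond the scatter) in this assay, so a change at this position moves the read-out with the nitro group kept. Compound 1 and compound 2 remain at a limit, and only compound 3 carries a number of its own: the limit of > 31600 nM in this assay, at which 2 of the 3 values shown sit.

On these data alone, the step between the nitro and bromo compounds cannot be read, so whether the exchange carries over to compound 2 stays open. Also open, as far as these compounds go, is how an amine or a carboxylic acid on that ring carbon would read.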